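The source may report more compounds than this note shows. Statements on the series, on what has been measured and on what is new or still open speak of the compounds shown alone.

Measured compounds:
Compound 2 `Cc1cccc(N2CCN(CCCCNc3nc(NCc4ccco4)c4cc(F)ccc4n3)CC2)c1C` — 3130 nM
Compound 1 `CCCCNc1nc(NCc2ccco2)c2cccc(F)c2n1` — "not determined" (no result reported)

In a functional assay on MCF7 cells (Homo sapiens) for cytotoxicity, read by MTT assay, with a stated time of 2 days (on this read-out lower numbers stand for stronger inhibition and higher numbers for weaker inhibition), compound 2 gives 3130 nM. For the measured compounds named here, this is the only number available: for compound 1 the entry reads "not determined" (no result reported), so there is nothing to compare compound 2 against, and no step between measured compounds can be drawn.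

Compound 3 `Cc1cccc(N2CCN(CCCCNc3nc(NCc4ccco4)c4ccccc4n3)CC2)c1C` differs from compound 2 in a single place: hydrogen in place of fluoro on an aromatic carbon. Nothing within this set shows what removing a fluoro from such a ring position does. The expectation therefore rests on the change itself, which is small. The step from compound 2 to compound 3 is therefore expected to stay within the usual scatter of this assay, with no clear direction. For compound 3 the estimated result in this assay is 3500 nM, with a range from 1500 nM to 8000 nM, which corresponds to an expected step of a 1.1-fold higher number from compound 2 to compound 3 (0.05 log units; within the scatter).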

Compound 3, half-maximal inhibitory concentration: 3140 nM
Compound 3: middle estimate off by 1.1-fold (0.05 log units), on the high side; the range from low to high includes it.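

Replacing fluoro with hydrogen gives a 1.0-fold higher number from compound 2 to compound 3 (0.00 log units; within the scatter) in this assay, the first comparison available in this set. At this aromatic carbon, meta to a fused ring and para to a fused ring, the fluoro therefore makes no difference that can be told from the scatter, and compound 3 matches compound 2 without it. Nothing in the data shown explains this match.

Going by these compounds, this single swap involves only a fluorine atom and a hydrogen atom, so it remains open whether a methoxy group, an amine or a carboxylic acid on the same carbon would change the result. On these data alone, it also remains open whether a fluoro on another carbon of this ring would behave in the same way.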